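The compounds below may be only part of what the source reports. "The series", "measured", "known", "first", "only" and "open" are said of these compounds alone.

Compound 2 `CN(C)CC[C@H](CSc1ccccc1)Nc1ccc(S(=O)(=O)NC(=O)c2ccc(N3CCN(Cc4ccccc4-c4ccc(Cl)cc4)CC3)cc2)cc1S(=O)(=O)C(F)(F)F` was tested in an assay on isolated protein for displacement of a labelled ligand from Apoptosis regulator Bcl-2 (Homo sapiens), read by fluorescence polarization; a higher number here means a weaker inhibitor, a lower number a stronger inhibitor. In this assay compound 2 gives < 1 nM, which is a limit of the assay rather than a number. Compound 1 `CN(C)CC[C@H](CSc1ccccc1)Nc1ccc(S(=O)(=O)NC(=O)c2ccc(N3CCN(Cc4ccccc4-c4ccc(Cl)cc4)CC3)cc2)cc1C(F)(F)F` shares the same core, carrying a trifluoromethyl group where compound 2 carries a (trifluoromethyl)sulfonyl group. In this assay compound 1 gives < 1 nM, again a limit of the assay. The step that the two limits leave unreadable from compound 1 to compound 2 therefore cannot be read in size, since (the limit of < 1 nM in this assay, at which 2 of the 2 values shown sit). Compound 3 `CN(C)CC[C@H](CSc1ccccc1)Nc1ccc(S(=O)(=O)NC(=O)c2ccc(N3CCN(Cc4ccccc4-c4ccc(Cl)cc4)CC3)cc2)cc1C(=O)C(F)(F)F` is not yet measured; it differs from compound 2 by (trifluoromethyl)carbonyl in place of (trifluoromethyl)sulfonyl on an aromatic carbon. Within the data shown here, no measured step bears directly on this change, and the one step available, from a trifluoromethyl group to a (trifluoromethyl)sulfonyl group, shows only that both partners sit at the limit. Compound 3 is expected to stay close to that limit, with a step of a number no lower from compound 2 to compound 3 (the limit leaves the size open) that may be none beyond the scatter. The estimate for compound 3 is 1 nM, within 0.2 nM to 5 nM.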

Compound 3, inhibition constant: < 1 nM
Compound 3: a limit, no number; the forecaster's own chance of this, stated with the estimate: 55%; the middle value lies on the limit itself.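

In this assay, among these compounds, compound 3 is again a limit rather than a number, so no step among compound 1, compound 2 and compound 3 can be read in size: the limit of < 1 nM in this assay, at which 3 of the 3 values shown sit. On these data alone, whether the trifluoromethyl, (trifluoromethyl)sulfonyl and (trifluoromethyl)carbonyl groups differ at all in this assay stays open.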